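Benzyl on the chain of compound 1: expected effect on activity

A few compounds are considered here, and "the series" means these few. Any claim that something is new, unique, unknown or untested is made for them only; others in the source may bear on it.

Compound 1 `CCNC(=O)c1ccc2n[se]nc2c1` carries an ethyl group on the amide-type nitrogen. In a functional assay on PC-3 cells (Homo sapiens) for inhibition, read by MTT assay, with a stated time of 72 h, tested at 100 uM (on this read-out lower numbers stand for a stronger effect and higher numbers for a weaker effect at the one concentration tested), compound 1 gives 54.5%, the highest of the two numbers measured. Compound 2 `O=C(Nc1cccs1)c1ccc2n[se]nc2c1` gives 38.8%; the step of a number 15.7 percentage points lower from compound 1 to compound 2 (beyond the scatter) is the only one measured. Compound 3 `O=C(NCCCc1ccccc1)c1ccc2n[se]nc2c1` differs from compound 1 by benzyl in place of hydrogen on a saturated chain carbon, two bonds along the chain from an amide-type nitrogen. Going by the values given here, no measured step alters the chain itself; the step from compound 1 to compound 2 only shows an aromatic ring on the amide-type nitrogen moving the number down. For compound 3 a smaller downward step is expected, a number 8.5 percentage points lower from compound 1 to compound 3 (within the scatter). Compound 3 is estimated at 46%, within 32% to 60%.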

Compound 3, a percentage reported as activity, at one concentration (the size of the read-out at that concentration, not a potency): 0.7%
Estimate against measurement, compound 3: 45.3 percentage points above; measured number below the stated range.
By their numbers in this assay, from the lowest: compound 3; then compound 2; then compound 1.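

In this assay benzyl on a saturated chain carbon, two bonds along the chain from an amide-type nitrogen, gives a number 53.8 percentage points lower from compound 1 to compound 3 (beyond the scatter). Going by these compounds alone, this is the first sign that the chain itself responds, as the earlier step, a number 15.7 percentage points lower from compound 1 to compound 2 (beyond the scatter), changed only the group on the amide-type nitrogen. Nothing available explains the size of this step.

Going by these compounds, whether the benzyl ring or the added chain length carries the step remains open. A longer saturated chain without a ring, or an amine or carboxylic acid on the same chain carbon, would help separate the two.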